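Macrophage tolerance notes on a small series

The source may hold more compounds than are shown below. What is called first, only, known or untested is meant among the compounds shown, and "the series" means these compounds.

Measured so far:
Compound 1 `c1ccc(Cc2nnc(Cn3nnc4ccccc43)o2)cc1` gives > 100000 nM in an ADME assay on cells (Macrophage, Homo sapiens) for inhibition; a higher number here means that more compound is tolerated, a lower number that less compound is tolerated; this is a limit of the assay, not a number.
Compound 2 `COc1cccc(Cc2nnc(Cn3nnc4ccccc43)o2)c1` gives > 100000 nM in this assay; this is again a limit of the assay.

Compound 1 therefore stands only at a limit on the numbers shown, and the one other value shown is a limit as well. Among the measured compounds shown here, the single measured step, a step that the two limits leave unreadable from compound 1 to compound 2, puts methoxy in place of hydrogen on an aromatic carbon; its size cannot be read, since both of its ends sit at the limit of > 100000 nM in this assay, at which 2 of the 2 values shown sit.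

Compound 3 `Brc1cccc(-c2nnc(Cn3nnc4ccccc43)o2)c1` is not yet measured. It differs from compound 1 by 3-bromophenyl in place of benzyl on an aromatic carbon. For the measured compounds named here, no measured step bears on this change, and the one step that is measured is unreadable, so nothing argues for a shift in either direction beyond the scatter.

Compound 3 is expected to give about 100000 nM in this assay, within a range of 30000 nM to 300000 nM. The step from compound 1 to compound 3 is thus estimated as a number no higher from compound 1 to compound 3 (the limit leaves the size open), most likely reported again only as a limit.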

Compound 3, half-maximal cytotoxic concentration: > 100000 nM
Compound 3: no number, only a limit (the forecaster's own chance of this, stated with the estimate: 75%); the middle value lies on the limit itself.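

In this assay compound 3 gives > 100000 nM, which is a limit of the assay. No new step can be read between compound 1 and compound 3, because both ends sit at a limit: the limit of > 100000 nM in this assay, at which 3 of the 3 values shown sit.

The compounds shown leave open whether methoxy or 3-bromophenyl changes tolerance at all.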